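Cytotoxicity notes: fluoro in place of hydrogen

The source may report more compounds than this note shows. Statements on the series, on what has been measured and on what is new or still open speak of the compounds shown alone.

Measured so far:
compound 1, `Cn1c(Cc2ccccc2C(F)(F)F)nc(C(=O)NCc2cccnc2)c(O)c1=O`, in an ADME assay on HepG2 cells (Homo sapiens) for cytotoxicity, in the presence of a further agent that is not named here (on this read-out lower numbers stand for stronger inhibition and higher numbers for weaker inhibition), gives > 100000 nM, a limit.
compound 2, `Cn1c(Cc2ccccc2C(F)(F)F)nc(C(=O)NCc2ccccn2)c(O)c1=O`, in this assay gives > 100000 nM, a limit.
compound 3, `Cn1c(Cc2ccccc2C(F)(F)F)nc(C(=O)NCc2ccccc2)c(O)c1=O`, in this assay gives > 100000 nM, a limit.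

All three compounds share the core of compound 1 and differ only in the group on the saturated chain carbon bound to the amide-type nitrogen. Each sits at the limit, as the limit of > 100000 nM in this assay, at which 3 of the 3 values shown sit, records, so the steps a step that the two limits leave unreadable from compound 1 to compound 2, a step that the two limits leave unreadable from compound 1 to compound 3 and a step that the two limits leave unreadable from compound 2 to compound 3 give no size. Compound 3 therefore stands at a limit in this assay, with no number behind it.

Compound 4, `Cn1c(Cc2ccccc2C(F)(F)F)nc(C(=O)NCc2ccc(F)cc2)c(O)c1=O`, differs from compound 3 by fluoro in place of hydrogen on an aromatic carbon. Among the compounds with values here, no measured step bears on this change with a readable size, so no shift beyond the scatter is expected; the step of a number no higher from compound 3 to compound 4 (the limit leaves the size open) is a nominal expectation. Compound 4 is estimated at 100000 nM in this assay, within 40000 nM to 300000 nM, most likely reported again as a limit.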

Compound 4, half-maximal inhibitory concentration: > 100000 nM
Compound 4: only a limit was reported; the forecaster's own chance of this, stated with the estimate: 85%; the middle value lies on the limit itself.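

Compound 4 sits at a limit, as do compound 1, compound 2 and compound 3, so no step among them can be read: the limit of > 100000 nM in this assay, at which 4 of the 4 values shown sit.

The compounds shown leave open what size, if any, fluoro in place of hydrogen has in this assay.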